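A Pyridin-3-yl Amide Predicted From Three Inactive Analogues

A few compounds are considered here, and "the series" means these few. Any claim that something is new, unique, unknown or untested is made for them only; others in the source may bear on it.

Three amides built on one shared core were tested in a functional assay on MDA-MB-231 cells (Homo sapiens) for antiproliferative activity, read by MTT assay, with stated times of 72 h and 4 h; a higher number here means a weaker inhibitor, a lower number a stronger inhibitor. Compound 1 `Cc1cc(Cl)ccc1C(=O)Nc1ccc(Cl)c(-c2nnc3c(Cl)cccn23)c1` gives > 100000 nM, which is a limit of the assay and not a number. Compound 2 `O=C(Nc1ccc(Cl)c(-c2nnc3c(Cl)cccn23)c1)c1ccon1` also reaches only a limit, giving > 100000 nM. Compound 3 `O=C(Nc1ccc(Cl)c(-c2nnc3c(Cl)cccn23)c1)c1ccc(C(F)(F)F)cc1Cl` likewise stops at a limit, with > 100000 nM. For the measured compounds named here, the step that the two limits leave unreadable from compound 1 to compound 2 cannot be read because the limit of > 100000 nM in this assay, at which 3 of the 3 values shown sit, covers both of its ends, so no measured step tells how a change at the carbonyl carbon moves potency here.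

Compound 4 `O=C(Nc1ccc(Cl)c(-c2nnc3c(Cl)cccn23)c1)c1cccnc1` has not yet been measured. It differs from compound 2 by pyridin-3-yl in place of 1,2-oxazol-3-yl on a carbonyl carbon. Since every value in this series is a limit, nothing measured points to a direction for this change, and the step of a number no higher from compound 2 to compound 4 (the limit leaves the size open) is expected to be small or not readable. Compound 4 is therefore expected to give 100000 nM in this assay, with a range from 20000 nM to 300000 nM, and most likely to be reported again only as a limit.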

Compound 4, half-maximal inhibitory concentration: > 100000 nM
Compound 4: a limit, no number (the forecaster's own chance of this, stated with the estimate: 80%); the middle value lies on the limit itself.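

The steps joining compound 4 to compound 1 and to compound 2 cannot be read, as both ends of each are limits and not numbers: the limit of > 100000 nM in this assay, at which 4 of the 4 values shown sit. The compounds shown leave open whether any change on the carbonyl carbon of the shared core moves potency in this assay.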